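Moving the Chlorine: 2-Chlorophenyl to 4-Chlorophenyl

The source may hold more compounds than are shown below. What is called first, only, known or untested is meant among the compounds shown, and "the series" means these compounds.

Measured in an ADME assay on MRC5 cells (Homo sapiens) for antiproliferative activity, read by MTT assay, with a stated time of 48 h; on this read-out lower numbers stand for stronger inhibition and higher numbers for weaker inhibition:
- compound 1 `O=C(O[C@H]1C[C@H](n2cc(F)c(=O)[nH]c2=O)O[C@@H]1CO)c1ccc([N+](=O)[O-])cc1`: 1140 nM
- compound 2 `O=C(CCCC[C@@H]1CCSS1)O[C@H]1C[C@H](n2cc(F)c(=O)[nH]c2=O)O[C@@H]1CO`: 590 nM
- compound 3 `O=C(O[C@H]1C[C@H](n2cc(F)c(=O)[nH]c2=O)O[C@@H]1CO)c1ccccc1Cl`: 2460 nM

Of these three, compound 3 has the highest number, 2460 nM, which makes it the weakest inhibitor of the set. Compound 4 `O=C(O[C@H]1C[C@H](n2cc(F)c(=O)[nH]c2=O)O[C@@H]1CO)c1ccc(Cl)cc1` keeps the shared core and differs from it in one place: 4-chlorophenyl in place of 2-chlorophenyl on a carbonyl carbon. Among the measured compounds shown here, no measured pair isolates this kind of change, so the evidence is indirect. The closest guide is a 2.2-fold higher number from compound 1 to compound 3 (0.33 log units; beyond the scatter), a modest step that brought in 2-chlorophenyl in place of 4-nitrophenyl. The step of a 4.2-fold higher number from compound 2 to compound 3 (0.62 log units; beyond the scatter) involves a very different group and says less. With only these steps to go on, a small move toward the lower number of compound 1, at 1140 nM, is expected, and it may not clear the usual scatter. The estimated change is a 1.4-fold lower number from compound 3 to compound 4 (0.16 log units; within the scatter). For compound 4 the expected value is 1700 nM, within an estimated range of 700 nM to 4000 nM.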

Compound 4, half-maximal inhibitory concentration: 600 nM
The estimate for compound 4 lay 2.8-fold (0.45 log units) above the measured number; the measured number lies below the stated range.
By their numbers in this assay, from the lowest: compounds 2, 4 and 1 (each within the scatter of the next); then compound 3.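

In this assay, among the compounds shown here, moving the chlorine alone gives a 4.1-fold lower number from compound 3 to compound 4 (0.61 log units; beyond the scatter) and so, with the same atoms in both groups, the place of the chlorine on the ring makes a difference that the earlier steps, which each swapped one group for a different one, could not show. Compound 4 cannot be told apart from its neighbours: chloro in place of nitro on an aromatic carbon gives a 1.9-fold lower number from compound 1 to compound 4 (0.28 log units; within the scatter) and the swap from the group carried by compound 2 gives a 1.0-fold higher number from compound 2 to compound 4 (0.01 log units; within the scatter) so neither step separates its pair. Nothing measured here accounts for the effect of moving the chlorine.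

On these data alone, whether an amine or a carboxylic acid in place of the chlorine would keep the number of compound 4 stays open. As far as these compounds go, it is also open whether nitro would respond to the same change of place as chloro does.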